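Replacing the amide-bearing side chain with a tolyl group

The source may report more compounds than this note shows. Statements on the series, on what has been measured and on what is new or still open speak of the compounds shown alone.

The shared core of compound 1 `CCOC(=O)C1=Cc2ccccc2OC1(OCc1cn(CC(=O)NC2CCCCC2)nn1)C(F)(F)F`, compound 2 `CCOC(=O)C1=Cc2ccccc2OC1(OCc1cc(-c2ccc(OC)cc2)no1)C(F)(F)F` and compound 3 `CCOC(=O)C1=Cc2ccccc2OC1(OCc1cc(-c2cccc(C(F)(F)F)c2)no1)C(F)(F)F` is tested in a functional assay on A549 cells (Homo sapiens) for inhibition, read by MTT assay, with a stated time of 24 h; a lower number here means a stronger inhibitor, a higher number a weaker inhibitor. Compound 1 gives 9900 nM, the lowest of the two numbers shown. Compound 3 gives 48600 nM. For compound 2 the assay reports only a limit, > 150000 nM. The step of an at least 3.0-fold lower number from compound 2 to compound 3 (0.48 log units; beyond the scatter) concerns a different ring than the change now followed. Compound 4 `CCOC(=O)C1=Cc2ccccc2OC1(OCc1cn(-c2ccc(C)cc2)nn1)C(F)(F)F` differs from compound 1 by 4-methylphenyl in place of (cyclohexylcarbamoyl)methyl on an aromatic nitrogen. Within the data shown here, no measured step touches this position, so the expected size is uncertain. Compound 4 is estimated at 20000 nM, in this assay between 4000 nM and 100000 nM, meaning an expected step of a 2.0-fold higher number from compound 1 to compound 4 (0.31 log units; beyond the scatter).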

Compound 4, half-maximal inhibitory concentration: 19700 nM
Beside the measured number, compound 4's estimate is 1.0-fold (0.01 log units) above it; measured number inside the range.
By their numbers in this assay, from the lowest: compounds 1 and 4 (each within the scatter of the next); then compound 3. At a limit, above all of these: compound 2.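

In this assay the swap gives a 2.0-fold higher number from compound 1 to compound 4 (0.30 log units; within the scatter), so on this aromatic nitrogen, (cyclohexylcarbamoyl)methyl and 4-methylphenyl cannot be told apart. For this pair, then, the hydrogen-bond donor and acceptor counted in the side chain that leaves are not needed to stay in this range of numbers. Nothing shown here gives a reason for this result.

Still open, as far as these compounds go, is whether this nitrogen accepts very different groups, such as a plain methyl, a longer chain ending in an amine, or a phenyl ring carrying a carboxylic acid.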